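A few compounds are considered here, and "the series" means these few. Any claim that something is new, unique, unknown or untested is made for them only; others in the source may bear on it.

Measured so far:
Compound 1, `CCOC(=O)c1oc2c(C(N)=O)c(OC)cc(OC)c2c1C`: "not active" (no number reported)
Compound 2, `COc1cc(OC)c2c(C)c(C(=O)NCc3ccccc3)oc2c1C(N)=O`: > 81400 nM

In a functional assay on NSCLC-N6 cells (Homo sapiens) for cytotoxicity, read by MTT assay (a lower number here means a stronger inhibitor, a higher number a weaker inhibitor), compound 1 gives "not active" (no number reported), with no number reported. Compound 2 gives only a limit of the assay, > 81400 nM. Compound 2 therefore stands at the limit of > 81400 nM in this assay, at which 1 of the 2 values shown sits, without a measurable number of its own. Compound 3, `COc1cc(OC)c2c(C)c(C(N)=O)oc2c1C(N)=O`, differs from compound 2 by hydrogen in place of benzyl on an amide-type nitrogen; in other words, benzylamino becomes amino. Within the data shown here, no step between two measured compounds is available, so there is no measured size to lean on. Both measured results show no activity, and compound 3 is expected to follow this, with a step that the limit leaves unreadable from compound 2 to compound 3 that is expected to stay within the scatter. Compound 3 is estimated at 100000 nM, within 40000 nM to 300000 nM, most likely reported again as a limit rather than a number.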

Compound 3, half-maximal inhibitory concentration: 22600 nM
The estimate for compound 3 lay 4.4-fold (0.65 log units) above the measured number; the whole stated range lies above it.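

In this assay, hydrogen in place of benzyl on the amide-type nitrogen gives an at least 3.6-fold lower number from compound 2 to compound 3 (0.55 log units; beyond the scatter), so this position does respond to a change, and the smaller amino group goes with the stronger inhibitor. Compound 3 is the first compound shown to give a measured number rather than no number or a limit. The true size of the step stays unknown because compound 2 has only a limit: the limit of > 81400 nM in this assay, at which 1 of the 3 values shown sits.

From the compounds shown here alone, whether a small group such as methyl on that nitrogen would keep this gain stays open. So does the effect of a longer chain such as propyl, or of a carboxylic acid in place of the amide.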